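Working notes: replacing 2-ethylphenyl with 4-nitrobenzyl

A few compounds are considered here, and "the series" means these few. Any claim that something is new, unique, unknown or untested is made for them only; others in the source may bear on it.

In a functional assay on MCF7 cells (Homo sapiens) for antiproliferative activity, read by MTT assay (a higher number here means a weaker inhibitor, a lower number a stronger inhibitor), compound 1 `CC1(C)CCc2c(ccc(C(=O)/C=C/c3ccc(OCc4cn(-c5ccc(Br)cc5)nn4)cc3)c2O)O1` is recorded as "not active" (no number reported) with no number attached. Among the measured compounds shown here, compound 2 `Cc1c(-n2cc(COc3ccc(/C=C/C(=O)c4ccc5c(c4O)CCC(C)(C)O5)cc3)nn2)cccc1[N+](=O)[O-]` gives 145000 nM as the only number so far. Compound 3 `CCc1ccccc1-n1cc(COc2ccc(/C=C/C(=O)c3ccc4c(c3O)CCC(C)(C)O4)cc2)nn1` is recorded as "not active" (no number reported) and so has no single number to its name, and compound 1 is the one further entry of that kind. Still unmeasured is compound 4 `CC1(C)CCc2c(ccc(C(=O)/C=C/c3ccc(OCc4cn(Cc5ccc([N+](=O)[O-])cc5)nn4)cc3)c2O)O1` which shares its core with compound 3.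

The structural change is 4-nitrobenzyl in place of 2-ethylphenyl on an aromatic nitrogen with 4-nitrobenzyl in place of 2-ethylphenyl on an aromatic nitrogen. For the measured compounds named here, no measured pair differs in one place, so nothing sizes this change directly. In this assay only a small step toward the stronger side is expected, and a second look at the series suggests that compound 4 stays a weak inhibitor. The nearest guide is compound 2 at 145000 nM which also carries a nitro group. A result with no number remains nearly as likely as a number. Compound 4 is estimated at 90000 nM within an expected range of 25000 nM to 250000 nM if a number is reported at all.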

Compound 4, half-maximal inhibitory concentration: 17100 nM
Compound 4: the middle estimate sits 5.3-fold (0.72 log units) above what was measured; the measured number lies below the stated range.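

In this assay, among the compounds shown here, compound 4, with 4-nitrobenzyl on the aromatic nitrogen, gives 17100 nM, while compound 3, with 2-ethylphenyl at that place, is recorded as "not active", so this swap has no size and shows only that a number appears where none stood. For the compounds shown here, the first sized change at this place comes from replacing 2-methyl-3-nitrophenyl with 4-nitrobenzyl, which gives an 8.5-fold lower number from compound 2 to compound 4 (0.93 log units; beyond the scatter), so with the shared core unchanged, the group on this nitrogen moves the read-out beyond the scatter, although compound 4 is still a micromolar-range entry by its printed value. Nothing measured here accounts for this step.

The compounds shown leave open how much of the step goes with the benzyl form and how much with where the nitro group stands, as compound 2 and compound 4 differ in both at once. Also open, as far as these compounds go, is how the read-out responds to an unsubstituted benzyl, a 4-aminobenzyl, a 4-carboxybenzyl or a longer chain such as 2-phenylethyl on the same nitrogen.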